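The compounds below may be only part of what the source reports. "The series", "measured", "known", "first", "only" and "open" are said of these compounds alone.

Compound 1 `Cc1ccc(NC(=O)N[C@H]2CC[C@H](Oc3ccc(F)cc3)CC2)cc1` is the 4-methylphenyl member of the series. In a functional assay on CRL2813 cells (Homo sapiens) for cytotoxicity, read by sulforhodamine B assay, with a stated time of 5 days (a lower number here means a stronger inhibitor, a higher number a weaker inhibitor), compound 1 gives > 20000 nM, which is a limit of the assay and not a number. Compound 2 `O=C(Nc1cccc(F)c1)N[C@H]1CC[C@H](Oc2ccc(F)cc2)CC1` gives 8300 nM in this assay, and compound 3 `COc1cccc(NC(=O)N[C@H]2CC[C@H](Oc3ccc(F)cc3)CC2)c1` gives 14000 nM. The step of an at least 2.4-fold lower number from compound 1 to compound 2 (0.38 log units; beyond the scatter) and the step of an at least 1.4-fold lower number from compound 1 to compound 3 (0.15 log units; that floor lies within the scatter) both start from the limit of > 20000 nM in this assay, at which 1 of the 3 values shown sits, so only their floors are known; the step of a 1.7-fold higher number from compound 2 to compound 3 (0.23 log units; within the scatter) lies within the scatter. Compound 4 `O=C(Nc1ccccc1)N[C@H]1CC[C@H](Oc2ccc(F)cc2)CC1` differs from compound 1 by hydrogen in place of methyl on an aromatic carbon. Among the measured compounds shown here, both measured steps from compound 1 alter the aryl group and give lower numbers, but neither removes a group outright, so no measured step matches this change exactly. The expected step of an at least 1.3-fold lower number from compound 1 to compound 4 (0.12 log units; that floor lies within the scatter) is accordingly small, with a modest lowering as the more likely direction and a repeat of the limit well possible. Compound 4 is expected to give 15000 nM in this assay, within the range 6000 nM to 40000 nM.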

Compound 4, half-maximal inhibitory concentration: 20000 nM
Estimate against measurement, compound 4: 1.3-fold (0.12 log units) below; measured number inside the range.
By their numbers in this assay, from the lowest: compounds 2, 3 and 4 (each within the scatter of the next, the first and the last beyond it).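

Compound 4 gives the series an unsubstituted phenyl reference in this assay. Hydrogen in place of fluoro on an aromatic carbon gives a 2.4-fold higher number from compound 2 to compound 4 (0.38 log units; beyond the scatter), a modest step, whereas hydrogen in place of methoxy gives a 1.4-fold higher number from compound 3 to compound 4 (0.15 log units; within the scatter), so of the two substituents with readable steps to hydrogen, only the fluoro of compound 2 separates from compound 4. Compound 1 gives > 20000 nM, which is a limit of the assay and not a number. Hydrogen in place of methyl on an aromatic carbon gives a number no higher from compound 1 to compound 4 (the limit leaves the size open), so the effect of removing the methyl stays unknown: the limit of > 20000 nM in this assay, at which 1 of the 4 values shown sits.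

From the compounds shown here alone, whether an amine or a carboxylic acid on this aryl group would move the number further than fluoro does remains open. Also open, going by these compounds, is whether changes elsewhere in the shared core would move the number with the phenyl of compound 4 held constant.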